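Replacing a chlorinated ring on the sulfonamide of compound 2

The source may report more compounds than this note shows. Statements on the series, on what has been measured and on what is new or still open speak of the compounds shown alone.

Three benzoxazole sulfonamides have been measured in an assay on cells for inhibition of HSP60/HSP10 (Homo sapiens), with a stated time of 60 min; a lower number here means a stronger inhibitor, a higher number a weaker inhibitor. Compound 1 `O=S(=O)(Nc1ccc2oc(-c3ccc(NS(=O)(=O)c4cccc5nonc45)cc3)nc2c1)c1ccc(Cl)s1` gives 13000 nM. Compound 3 `O=S(=O)(Nc1ccc2oc(-c3ccccc3)nc2c1)c1cccs1` gives 90000 nM. Compound 2 `O=S(=O)(Nc1ccc(-c2nc3ccccc3o2)cc1)c1ccccc1Cl` returns only a limit of the assay, > 100000 nM, so its true potency is not pinned to a number. Compound 2 therefore stands at the weak end of what has been seen, at the limit of > 100000 nM in this assay, at which 1 of the 3 values shown sits, while compound 1 and compound 3 have definite, though still weak, values.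

The step from compound 2 leads to compound 4 `CCc1ccc(S(=O)(=O)Nc2ccc(-c3nc4ccccc4o3)cc2)cc1`. The change is 4-ethylphenyl in place of 2-chlorophenyl on a sulfonyl sulfur. Within the data shown here, no measured pair in this set shows the effect of such a swap on the sulfonyl sulfur, so the only guide is that every compound here sits at weak potency, with compound 3 and its thiophene sulfonyl at 90000 nM being the nearest comparison.

Compound 4 is estimated to give 60000 nM, within a range from 15000 nM to 250000 nM. This estimate implies an expected change of an at least 1.6-fold lower number from compound 2 to compound 4 (0.22 log units; that floor lies within the scatter), in the direction of a somewhat stronger inhibitor, but a result that again comes back only as a limit would not be surprising.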

Compound 4, half-maximal inhibitory concentration: > 100000 nM
Compound 4 gave a limit, no number (the forecaster's own chance of this, stated with the estimate: 45%); at least 1.6-fold (0.22 log units) between middle value and limit.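

Compound 2 and compound 4 both return only a limit of the assay, so the swap of 2-chlorophenyl for 4-ethylphenyl cannot be read as a step: the limit of > 100000 nM in this assay, at which 2 of the 4 values shown sit. The compounds shown leave open whether any other group on that sulfonyl sulfur, with the rest of compound 2 kept, would give a definite number.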